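Working notes: methoxy to methyl, cytotoxicity limits

This account rests on a few compounds, and the source may have more. Where it says the series, first, only, none or still open, it means among the compounds named here.

Measured so far:
Compound 1 `COc1ccccc1[S+]([O-])c1cccc(N)c1C#N` gives > 200000 nM in a functional assay on MT4 cells (Homo sapiens) for cytotoxicity (a lower number here means a stronger inhibitor, a higher number a weaker inhibitor), a limit.
Compound 2 `Cc1ccccc1[S+]([O-])c1cccc(N)c1C#N` gives > 200000 nM in this assay, a limit.
Compound 3 `COc1ccc(S(=O)(=O)c2cccc(N)c2C#N)cc1` gives > 200000 nM in this assay, a limit.

Across the pair of compound 1 and compound 2 the change is methyl in place of methoxy on an aromatic carbon. The step that the two limits leave unreadable from compound 1 to compound 2 cannot be sized, as both ends sit at the limit. Compound 4 `Cc1ccc(S(=O)(=O)c2cccc(N)c2C#N)cc1` is not yet measured; it differs from compound 3 by methyl in place of methoxy on an aromatic carbon. This is the same kind of change as from compound 1 to compound 2, but the place is not the same word for word: ortho to a large group in the first pair, para to a large group in the second. The difference between the core of compound 1 and the core of compound 3 is not broken down here.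

Among the compounds with values here, the only evidence is the limit of > 200000 nM in this assay, at which 3 of the 3 values shown sit. On that basis the step that the limit leaves unreadable from compound 3 to compound 4 is expected to be unreadable as well, since compound 3 sits at the limit with > 200000 nM. Compound 4 is therefore estimated at 250000 nM, between 100000 nM and 1000000 nM, most likely again reported only as a limit.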

Compound 4, half-maximal inhibitory concentration: > 200000 nM
Compound 4 was reported as a limit; the forecaster's own chance of this, stated with the estimate: 85%; the middle value lies beyond the limit too.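

Compound 4 gives > 200000 nM in this assay, a limit. With compound 3 also reported only as a limit, no step can be read between compound 3 and compound 4. The compounds shown leave open how far any of them lies from that limit, and whether methyl in place of methoxy changes cytotoxicity at all.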